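The source may hold more compounds than are shown below. What is called first, only, known or untested is meant among the compounds shown, and "the series" means these compounds.

Compound 1 `O=C1CSC(c2ccc(Cl)cc2)N1CCN1CCCCC1` is the starting point of this account. In an ADME assay on Vero cells (Chlorocebus sabaeus) for cytotoxicity, read by neutral red uptake, tested at 49 ug/mL (on this read-out higher numbers stand for a weaker effect at the one concentration tested and lower numbers for a stronger effect), compound 1 gives 84%, the lowest of the three numbers recorded. Compound 2 `O=C1CSC(c2ccccc2Cl)N1CCN1CCCCC1` gives 100% in this assay, and compound 3 `O=C1CSC(c2c(Cl)cccc2Cl)N1CCN1CCCCC1` gives 100%. The step of a number 16 percentage points higher from compound 1 to compound 2 (beyond the scatter) shifts the chloro from one aromatic carbon to another, and the step of no change at the digits printed from compound 2 to compound 3 (within the scatter) adds a second chloro. Compound 4 `COc1ccc(C2SCC(=O)N2CCN2CCCCC2)cc1` has not yet been measured. It differs from compound 1 in a single place: methoxy in place of chloro on an aromatic carbon. Here a chloro leaves and a methoxy enters. Neither measured step involves a methoxy. The first shows only that moving the chloro raised the number by a modest amount, the second that an added chloro left the number unchanged. Within the data shown here, no measured step bears directly on the change from compound 1 to compound 4, so a modest rise, or no step beyond the scatter, is the most that can reasonably be expected. The step estimated is a number 8 percentage points higher from compound 1 to compound 4 (within the scatter), toward the weaker end of the read-out. Compound 4 is therefore expected to give 92% in this assay, within a range from 76% to 100%.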

Compound 4, a percentage reported as activity, at one concentration (the size of the read-out at that concentration, not a potency): 100%
Compound 4: middle estimate off by 8 percentage points, on the low side, within the range that was stated.
By their numbers in this assay, from the lowest: compound 1; then compounds 2, 3 and 4 (each within the scatter of the next).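

Exchanging the chloro for methoxy, on the aromatic carbon para to a large group, gives in this assay a number 16 percentage points higher from compound 1 to compound 4 (beyond the scatter). The earlier steps had changed the number only by moving a chloro away from this place, so they could not tell whether the place had to be left free of a group for the number to rise; here it stays occupied and the number rises all the same, which makes chloro, rather than just any group at this place, what goes with the lower number among these compounds. The data offer no measurement that accounts for this difference between chloro and methoxy.

The compounds shown leave open how other groups at this place would read in this assay, such as an amine, a carboxylic acid or a longer chain like ethoxy, and so whether chloro stands alone here or is one of several groups that give a lower number. They also leave open what methoxy would do on the other aromatic carbons, where so far only chloro appears.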